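A few compounds are considered here, and "the series" means these few. Any claim that something is new, unique, unknown or untested is made for them only; others in the source may bear on it.

Measured compounds and their values:

compound 1, `Oc1cccc(-c2cc(-c3ccc(Cl)cc3)nc(-c3ccco3)c2)c1`: 11400 nM
compound 2, `Oc1ccc(-c2cc(-c3ccc(Cl)cc3)nc(-c3ccco3)c2)cc1`: 7280 nM
compound 3, `Oc1ccc(-c2cc(-c3ccccc3)nc(-c3cccc(Cl)c3)c2)cc1`: 5360 nM

All three were tested in a functional assay on DU-145 cells (Homo sapiens) for cytotoxicity, read by CCK-8 assay and cell counting, with a stated time of 2 days; a lower number here means a stronger inhibitor, a higher number a weaker inhibitor. Compound 2 and compound 1 differ in one place only, (3-hydroxyphenyl in place of 4-hydroxyphenyl on an aromatic carbon). That change gave a 1.6-fold higher number from compound 2 to compound 1 (0.19 log units; within the scatter), so the two numbers cannot be told apart with confidence. Compound 3 carries a different core from compound 2, and the difference between the two cores is not broken down here; in this assay compound 3 gives 5360 nM, which sits within the scatter of compound 2.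

Compound 4, `Oc1cccc(-c2cc(-c3ccccc3)nc(-c3cccc(Cl)c3)c2)c1`, has not yet been measured. It arises from compound 3 by 3-hydroxyphenyl in place of 4-hydroxyphenyl on an aromatic carbon. Among the measured compounds shown here, this is the same kind of change as the one from compound 2 to compound 1, but not the same: in compound 2 the place is meta to a 4-chlorophenyl group and meta to a furan-2-yl group, whereas in compound 3 it is meta to a 3-chlorophenyl group and meta to a phenyl group.

For the measured compounds named here, with only one earlier example, the expectation is that moving the hydroxyl to the 3-position shifts the number modestly, roughly as it did from compound 2 to compound 1, because a 1.6-fold higher number from compound 2 to compound 1 (0.19 log units; within the scatter) was small. The expected step is a 1.6-fold higher number from compound 3 to compound 4 (0.20 log units; within the scatter). Compound 4 is therefore estimated at 8500 nM in this assay, with a likely range from 4000 nM to 18000 nM.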

Compound 4, half-maximal inhibitory concentration: 2750 nM
Compound 4: the middle estimate sits 3.1-fold (0.49 log units) above what was measured, and the stated range ends above it.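

In this assay, moving the hydroxyl so that 3-hydroxyphenyl stands in place of 4-hydroxyphenyl gave a 1.9-fold lower number from compound 3 to compound 4 (0.29 log units; within the scatter), so this step alone cannot be told apart from the ordinary spread of repeated measurements. Even so, the two steps for this change point in opposite directions, and the gap between them is larger than the scatter, so the effect seen on one core cannot simply be assumed to carry over to the other: the same change on two cores in this assay, a 1.6-fold higher number (0.19 log units; within the scatter) from compound 2 to compound 1 and a 1.9-fold lower number (0.29 log units; within the scatter) from compound 3 to compound 4, 3.1-fold (0.48 log units) apart, beyond the scatter of two such steps

Among the compounds shown here, this does not show which of the other groups on the two cores lies behind the gap, since those cores differ in more than one place, and with only two pairs it gives no general rule about which hydroxyl position is better.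

The compounds shown leave open how the same change would behave on a third core, which would help show whether the gap follows one particular group. They also leave open how the number would respond if an amine or a carboxylic acid took the place of the hydroxyl on this phenyl ring, since every compound here carries a hydroxyl at that point.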